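The source may report more compounds than this note shows. Statements on the series, on what has been measured and on what is new or still open speak of the compounds shown alone.

Of the compounds shown here, three have been measured in a functional assay (Homo sapiens) for inhibition of Nucleic Acid, tested at 100 uM; a lower number here means less inhibition, a higher number more inhibition at the concentration tested (going by the name of the read-out). Compound 1 `CSc1[nH]ccc2ncnc1-2` gives 4%, compound 2 `OC[C@H]1OC(n2cnc3c(SCc4ccccc4)nccc32)[C@H](O)[C@@H]1O` gives 30%, and compound 3 `[N-]=[N+]=Nc1nccc2c1ncn2[C@H]1C[C@H](O)[C@@H](CO)O1` gives 4%. Compound 3 stands level with compound 1 at the digits shown, and together the two are the lowest of the three numbers, lying within the usual scatter of each other. Compound 2 lies higher than compound 3 by an amount that goes beyond the scatter.

Compound 4 `OC[C@H]1O[C@@H](n2cnc3c(Cl)nccc32)C[C@@H]1O` has not yet been measured. It differs from compound 3 in one place: chloro in place of azido on an aromatic carbon. Going by the values given here, no measured pair in this set shows what such a change does on its own, so the expectation rests on the numbers that exist. Among the compounds with values here, compound 3 sits at the bottom of the range with 4%, and only one small group is exchanged. The step of a number 4 percentage points higher from compound 3 to compound 4 (within the scatter) is expected to be small and not beyond the scatter in either direction. Compound 4 is expected to give about 8% in this assay, with a likely range from 0% to 25%.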

Compound 4, a percentage reported as inhibition, at one concentration (the size of the read-out at that concentration, not a potency): 5%
Beside the measured number, compound 4's estimate is 3 percentage points above it; the range from low to high includes it.
By their numbers in this assay, from the lowest: compounds 1, 3 and 4 (each within the scatter of the next); then compound 2.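

In this assay, going by these compounds alone, chloro in place of azido on this aromatic carbon, next to the ring nitrogen, gives a number 1 percentage points higher from compound 3 to compound 4 (within the scatter), the first reading of a single change at this position. Azido has three heavy atoms and chloro only one, yet this difference in size of the group leaves the number within the scatter, so this assay does not tell the two groups apart on this core. Nothing measured here offers an explanation for this result.

On these data alone, whether an amine or a longer chain on this aromatic carbon would move the number beyond the scatter remains open. As far as these compounds go, it is also open whether the same exchange of azido for chloro would stay this small on a compound that reads higher in this assay.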